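The source may hold more compounds than are shown below. What is called first, only, known or untested is meant among the compounds shown, and "the series" means these compounds.

Compound 1, `CCc1nc(N)nc2c1c(-c1ccc3oc(N)nc3c1)nn2C(C)C`: in an ADME assay on cells (Hepatocyte, Homo sapiens) for metabolic stability, read by LC-MS, with a stated time of 90 min, tested at 1 uM (a lower number here means slower removal, a higher number faster removal of the compound), compound 1 gives < 5 uL/min, which is a limit of the assay and not a number.
Compound 2, `COc1nc(N)nc2c1c(-c1ccc3oc(N)nc3c1)nn2C(C)C`: in this assay compound 2 gives "not determined" (no result reported).
Compound 3, `CC(C)n1nc(-c2ccc3oc(N)nc3c2)c2c(Cl)nc(N)nc21`: in this assay compound 3 gives 11 uL/min.

Among the measured compounds shown here, compound 1 therefore stands only at a limit in this assay; compound 2 adds an entry without a number, and compound 3 carries the single measured number in the set, with the limit of < 5 uL/min in this assay, at which 1 of the 3 values shown sits, marking where compound 1 sits.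

Compound 4, `CC(C)n1nc(-c2ccc3oc(N)nc3c2)c2cnc(N)nc21`, differs from compound 1 as follows: hydrogen in place of ethyl on an aromatic carbon.

For the measured compounds named here, the one measured step that starts from compound 1 is an at least 2.2-fold higher number from compound 1 to compound 3 (0.34 log units; beyond the scatter), a change at the same aromatic carbon but to chloro rather than to hydrogen. Going by the values given here, no measured step takes ethyl to hydrogen. On that basis the expected step in this assay is a number no lower from compound 1 to compound 4 (the limit leaves the size open), a move upward from the limit that may stay within the scatter, with a fair chance that only a limit is again reported. The estimate for compound 4 is 5 uL/min, within a range from 2 uL/min to 15 uL/min.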

Compound 4, intrinsic clearance in a liver preparation (reported as CLH), per the amount of preparation that the assay uses: 150 uL/min
Compound 4: middle estimate off by 30-fold (1.48 log units), on the low side; the measured number lies above the stated range.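

In this assay, hydrogen in place of ethyl on this aromatic carbon gives an at least 30-fold higher number from compound 1 to compound 4 (1.47 log units; beyond the scatter), and hydrogen in place of chloro gives a 14-fold higher number from compound 3 to compound 4 (1.13 log units; beyond the scatter). The earlier step, between the two substituted compounds, did not show that compound 4, with only hydrogen at this carbon, stands well apart from both compound 1 and compound 3, so among these compounds either group goes with a much lower number. The entry for compound 1 is a limit of the assay and not a number: the limit of < 5 uL/min in this assay, at which 1 of the 4 values shown sits.

Steps to compound 2, with its methoxy group, cannot be read, as it has no reported result. Whether the low numbers extend to other groups at this carbon, such as methyl, an amine or a nitrile, remains open, as does any cause of the large steps.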